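Trimethoxyphenyl Ketone in a Weakly Cytotoxic Fused Series

This account rests on a few compounds, and the source may have more. Where it says the series, first, only, none or still open, it means among the compounds named here.

Of the compounds shown here, three sharing one core have been tested in a functional assay on A549 cells (Homo sapiens) for cytotoxicity, read by MTT assay, with a stated time of 48 h; on this read-out lower numbers stand for stronger inhibition and higher numbers for weaker inhibition. Compound 1 `COc1cc(-c2nnc3n2NC(c2ccco2)C(C(=O)c2ccc(F)c(F)c2)S3)cc(OC)c1OC` gives 93700 nM. Compound 3 `COc1cc(-c2nnc3n2NC(c2ccco2)C(C(=O)c2ccc(C(F)(F)F)cc2)S3)cc(OC)c1OC` gives 37200 nM. Compound 2 `COc1ccc(C(=O)C2Sc3nnc(-c4cc(OC)c(OC)c(OC)c4)n3NC2c2cccs2)cc1` reaches only a limit of the assay, > 100000 nM, so no number is known for it. Among the two numbers shown, compound 3 stands lowest, with compound 1 as the nearest neighbour. Within the data shown here, the one measured step, a 2.5-fold lower number from compound 1 to compound 3 (0.40 log units; beyond the scatter), was modest in size.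

Compound 4 `COc1cc(C(=O)C2Sc3nnc(-c4cc(OC)c(OC)c(OC)c4)n3NC2c2ccco2)cc(OC)c1OC` is not yet measured. It differs from compound 3 in a single place: 3,4,5-trimethoxyphenyl in place of 4-(trifluoromethyl)phenyl on a carbonyl carbon. Among the measured compounds shown here, no measured step exchanges a trifluoromethyl-bearing ring for a methoxy-bearing one at this carbonyl carbon, so the single step from compound 1 to compound 3 bears on it only loosely, showing that changing the aryl group at this position has so far moved this assay by a modest amount. Compound 2, which carries a methoxy-bearing ring at the same carbonyl carbon among other differences, sits at the limit (the limit of > 100000 nM in this assay, at which 1 of the 3 values shown sits).

The step of a 1.9-fold higher number from compound 3 to compound 4 (0.27 log units; within the scatter) is therefore expected to be small and most likely upward. Compound 4 is estimated at 70000 nM, within 25000 nM to 160000 nM, with a fair chance that only a limit is reported.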

Compound 4, half-maximal inhibitory concentration: 48300 nM
Beside the measured number, compound 4's estimate is 1.4-fold (0.16 log units) above it; the measured number falls inside the stated range.
By their numbers in this assay, from the lowest: compounds 3, 4 and 1 (each within the scatter of the next, the first and the last beyond it). At a limit, above all of these: compound 2.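

In this assay, the 3,4,5-trimethoxyphenyl group on the carbonyl carbon cannot be told apart from either fluorine-bearing aryl group, with a 1.3-fold higher number from compound 3 to compound 4 (0.11 log units; within the scatter) and a 1.9-fold lower number from compound 1 to compound 4 (0.29 log units; within the scatter). Until now, this position had been seen with a measured number only when it carried fluorine-bearing rings, whereas compound 4 shows that a ring with oxygen in place of fluorine, counted with 3 hydrogen-bond acceptors against 0 for 4-(trifluoromethyl)phenyl, stays within the scatter of both. Among these compounds, compound 4 therefore sits in the gap between compound 3 and compound 1, the only pair here that lies beyond the scatter of each other, so the three aryl groups do not split into two clear levels.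

On these data alone, whether an amine or a carboxylic acid on this ring would move the number beyond the scatter remains open. Compound 2 differs from compound 4 in more than one place and gives only a limit, so it cannot show what a single methoxy group on this ring would do: the limit of > 100000 nM in this assay, at which 1 of the 4 values shown sits.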